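The source may report more compounds than this note shows. Statements on the series, on what has been measured and on what is new or still open speak of the compounds shown alone.

Compound 1 `CCOC(=O)Nc1cc(NC(C)CCCN(CC)CC)c2nc(-c3ccco3)c(-c3ccco3)nc2n1` and compound 2 `CCOC(=O)Nc1cc(NC(C)CCCN(CC)CC)c2nc(-c3cccs3)c(-c3cccs3)nc2n1` share one core and differ only in the two aromatic groups attached to it. In an ADME assay on Vero cells (Chlorocebus sabaeus) for cytotoxicity, read by CellTiter-Glo, with a stated time of 72 h (a lower number here means that less compound is tolerated, a higher number that more compound is tolerated), compound 1 gives > 40000 nM, which is a limit of the assay rather than a number. Compound 2 gives > 40000 nM in this assay, again only a limit. Compound 2 therefore sits at the limit of > 40000 nM in this assay, at which 2 of the 2 values shown sit, alongside every other value shown. Compound 3 `CCOC(=O)Nc1cc(NCCCCN(CC)CC)c2nc(-c3cccs3)c(-c3cccs3)nc2n1` is not yet measured; it differs from compound 2 by hydrogen in place of methyl on a saturated chain carbon bound to a nitrogen on an aromatic ring and a saturated chain carbon. Among the measured compounds shown here, no measured step of this kind exists, so no shift beyond the scatter is expected in this assay. Compound 3 is expected to give 60000 nM, between 25000 nM and 150000 nM, a step that the limit leaves unreadable from compound 2 to compound 3.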

Compound 3, half-maximal cytotoxic concentration: > 40000 nM
Compound 3: only a limit was reported; the forecaster's own chance of this, stated with the estimate: 85%; the middle value lies beyond the limit too.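

Compound 2 and compound 3 both stop at a limit of the assay, so no step between them can be read: the limit of > 40000 nM in this assay, at which 3 of the 3 values shown sit.

The compounds shown leave open at what concentration any of them becomes toxic in this assay, and whether hydrogen in place of methyl shifts that concentration.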